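Pyridin-3-yl for 4-chlorophenyl on a second core

This account rests on a few compounds, and the source may have more. Where it says the series, first, only, none or still open, it means among the compounds named here.

compound 1 `Clc1ccc(-c2cc(-c3ccoc3)cc(-c3ccc(Cl)s3)n2)cc1` — 16500 nM
compound 2 `Clc1ccc(-c2cc(-c3ccoc3)cc(-c3cccnc3)n2)s1` — 20000 nM
compound 3 `Cc1ccsc1-c1cc(-c2ccc(Cl)o2)cc(-c2ccc(Cl)cc2)n1` — 29300 nM

In a functional assay on HeLa cells (Homo sapiens) for cytotoxicity, read by ELISA, with a stated time of 4 days (a lower number here means a stronger inhibitor, a higher number a weaker inhibitor), compound 1 gives 16500 nM and compound 2 gives 20000 nM. The change between them is pyridin-3-yl in place of 4-chlorophenyl on an aromatic carbon and it produced a 1.2-fold higher number from compound 1 to compound 2 (0.08 log units; within the scatter). Compound 3 gives 29300 nM in this assay; the difference between its core and the core of compound 1 is not broken down here, and all three measured numbers sit within the scatter of one another.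

Compound 4 `Cc1ccsc1-c1cc(-c2ccc(Cl)o2)cc(-c2cccnc2)n1` carries the same kind of change on the core of compound 3: pyridin-3-yl in place of 4-chlorophenyl on an aromatic carbon. The surroundings are not identical, since in compound 1 the place is meta to a 5-chlorothiophen-2-yl group and meta to a furan-3-yl group, whereas in compound 3 it is meta to a 3-methylthiophen-2-yl group and meta to a 5-chlorofuran-2-yl group, so it is the same kind of change, not the same change.

Within the data shown here, for compound 4 the expected step is a 1.2-fold higher number from compound 3 to compound 4 (0.08 log units; within the scatter), resting on the single measured instance a 1.2-fold higher number from compound 1 to compound 2 (0.08 log units; within the scatter). Compound 4 is therefore expected to give about 35000 nM in this assay, with a likely range from 15000 nM to 80000 nM.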

Compound 4, half-maximal inhibitory concentration: > 50000 nM
Compound 4: a limit, no number; the forecaster's own chance of this, stated with the estimate: 15%; middle value at least 1.4-fold (0.15 log units) from the limit.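

In this assay compound 4 gives > 50000 nM, which is a limit of the assay and not a number. On the second core, pyridin-3-yl in place of 4-chlorophenyl gives an at least 1.7-fold higher number from compound 3 to compound 4 (0.23 log units; that floor lies within the scatter). The pair shows that this change does not lower the number beyond the scatter on either core, but it does not show that the size of the step carries from one core to the other: the same change on two cores in this assay, a 1.2-fold higher number (0.08 log units; within the scatter) from compound 1 to compound 2 and an at least 1.7-fold higher number (0.23 log units; that floor lies within the scatter) from compound 3 to compound 4; the limit leaves it open whether they differ

As far as these compounds go, how far compound 4 lies past its limit remains open, so the true size of the second step is unknown, and the top of the measured range is already occupied by this compound: the limit of > 50000 nM in this assay, at which 1 of the 4 values shown sits. Also open is how this place on either core responds to a group other than these two aromatic rings, such as an aminomethyl group or a carboxylic acid, and whether pyridin-3-yl gives a similar step on any further core.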